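Adding a Methoxy Group to the Phenyl of Compound 2

A few compounds are considered here, and "the series" means these few. Any claim that something is new, unique, unknown or untested is made for them only; others in the source may bear on it.

Compound 2 `O=c1oc2ccccc2c(N2CCN(c3ccccc3)CC2)c1CO` stands at a limit of a functional assay on WM1361 cells (Homo sapiens) for inhibition, read by MTT assay, with a stated time of 24 h; a higher number here means a weaker inhibitor, a lower number a stronger inhibitor: its value of > 50000 nM is a limit, not a number. Compound 1 `CCN1CCN(c2c(CO)c(=O)oc3ccccc23)CC1` likewise gives only a limit, > 100000 nM. Within the data shown here, compound 3 `O=c1oc2ccccc2c(N2CCN(c3cccc(Cl)c3Cl)CC2)c1CO` is the sole compound with a number, 45900 nM. The steps between them read an at least 2.1-fold lower number from compound 1 to compound 3 (0.33 log units; beyond the scatter) and an at least 1.0-fold lower number from compound 2 to compound 3 (0.03 log units; that floor lies within the scatter), while a step that the two limits leave unreadable from compound 1 to compound 2. Compound 4 `COc1ccc(N2CCN(c3c(CO)c(=O)oc4ccccc34)CC2)cc1` differs from compound 2 by methoxy in place of hydrogen on an aromatic carbon. Among the measured compounds shown here, the only measured step that bears on changing this phenyl, an at least 1.0-fold lower number from compound 2 to compound 3 (0.03 log units; that floor lies within the scatter), has a floor within the scatter, so no move beyond the scatter is expected. Compound 4 is therefore expected to give about 50000 nM, between 20000 nM and 150000 nM. That estimate means an expected step of a number no higher from compound 2 to compound 4 (the limit leaves the size open), and a limit rather than a number remains likely.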

Compound 4, half-maximal inhibitory concentration: 40400 nM
Estimate against measurement, compound 4: 1.2-fold (0.09 log units) above; low and high end bracket the measured number.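

On the phenyl, methoxy gives a measured number where there was only a limit, with an at least 1.2-fold lower number from compound 2 to compound 4 (0.09 log units; that floor lies within the scatter) and the true size left open because the starting value is a limit: the limit of > 50000 nM in this assay, at which 1 of the 4 values shown sits. Changing the 2,3-dichlorophenyl to the 4-methoxyphenyl leaves this assay essentially unmoved, with a 1.1-fold lower number from compound 3 to compound 4 (0.06 log units; within the scatter) as the step. Replacing ethyl with the 4-methoxyphenyl gives an at least 2.4-fold lower number from compound 1 to compound 4 (0.39 log units; beyond the scatter) as a second substituted phenyl that clears the scatter. From the compounds shown here alone, whether an amine or a carboxylic acid at this place on the phenyl would move the number further remains open. So does the effect of methoxy elsewhere on that ring.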